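The source may report more compounds than this note shows. Statements on the series, on what has been measured and on what is new or still open speak of the compounds shown alone.

Among the measured compounds shown here, in a functional assay on BJAB cells (Homo sapiens) for antiproliferative activity, with a stated time of 4 days (a lower number here means that less compound is needed, a higher number that more compound is needed for the effect), compound 2 `Cc1nn(-c2nc(-c3ccc(Cl)c(Cl)c3)c(SC(C)C)s2)c(C(=O)O)c1-c1ccncc1` gives 5900 nM, the higher of the two numbers measured so far; compound 1 `Cc1cc(C)cc(-c2c(C)nn(-c3nc(-c4ccc(Cl)c(Cl)c4)c(SC(C)C)s3)c2C(=O)O)c1` gives 2700 nM. For the measured compounds named here, the one measured step, a 2.2-fold higher number from compound 1 to compound 2 (0.34 log units; beyond the scatter), shows the pyridin-4-yl ring raising the number beyond the scatter. Compound 3 `Cc1nn(-c2nc(-c3ccc(Cl)c(Cl)c3)c(SC(C)C)s2)c(C(=O)O)c1-c1ccccc1C(F)(F)F` turns that choice back: 2-(trifluoromethyl)phenyl in place of pyridin-4-yl on an aromatic carbon, so it carries a six-membered ring of carbon only, as compound 1 does, though bearing a trifluoromethyl rather than the 3,5-dimethylphenyl pattern. A modest fall in this assay is therefore expected, about a 2.0-fold lower number from compound 2 to compound 3 (0.29 log units; within the scatter). Compound 3 is estimated at 3000 nM, within a range from 1200 nM to 8000 nM.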

Compound 3, half-maximal effective concentration: 5200 nM
Estimate against measurement, compound 3: 1.7-fold (0.24 log units) below, within the range that was stated.
By their numbers in this assay, from the lowest: compounds 1, 3 and 2 (each within the scatter of the next, the first and the last beyond it).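

In this assay, 2-(trifluoromethyl)phenyl in place of pyridin-4-yl gives a 1.1-fold lower number from compound 2 to compound 3 (0.05 log units; within the scatter) and, set against 3,5-dimethylphenyl, gives a 1.9-fold higher number from compound 1 to compound 3 (0.28 log units; within the scatter) on the same aromatic carbon. Compound 3 thus stands within the scatter of both earlier compounds, so a ring of carbon only does not by itself separate it from compound 2, and this position accepts the 2-(trifluoromethyl)phenyl group without a step beyond the scatter. Nothing available explains these steps. Still open, from the compounds shown here alone, is how an amine on this aromatic ring, or a saturated cyclohexyl ring in its place, would compare.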